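The source may report more compounds than this note shows. Statements on the series, on what has been measured and on what is new or still open speak of the compounds shown alone.

Going by the values given here, compound 3 `S=C(NCc1cccnc1)SCCc1nnc(-c2ccccc2)o1` gives 2770 nM in a functional assay on MDA-MB-468 cells (Homo sapiens) for cytotoxicity, read by resazurin assay, with a stated time of 72 h (on this read-out higher numbers stand for weaker inhibition and lower numbers for stronger inhibition), the lowest of the three numbers measured so far. Its nearest neighbour is compound 2 `CC(=O)CCSC(=S)NCc1cccnc1`, which gives 4220 nM, a gap that lies within the scatter, so the two cannot be told apart. Compound 1 `N#CCCSC(=S)NCc1cccnc1` gives 9530 nM, a gap that lies beyond the scatter. Among the compounds with values here, the only measured step between close structures is a 2.3-fold lower number from compound 1 to compound 2 (0.35 log units; beyond the scatter), which concerns the end of the saturated chain.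

Compound 4 `Cc1cc(-c2nnc(CCSC(=S)NCc3cccnc3)o2)no1` differs from compound 3 in one place: 5-methyl-1,2-oxazol-3-yl in place of phenyl on an aromatic carbon. Within the data shown here, no measured step touches the aromatic group on the five-membered ring of the shared core, so the change has no direct precedent here; the one known step concerns a different part of the molecule and was only modest. The expectation is therefore no step beyond the scatter, which is what a 1.1-fold higher number from compound 3 to compound 4 (0.03 log units; within the scatter) means. Compound 4 is estimated at 3000 nM, with a range from 1200 nM to 7500 nM.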

Compound 4, half-maximal inhibitory concentration: 6140 nM
For compound 4 the middle estimate is 2.0-fold (0.31 log units) below the measured one; the measured number falls inside the stated range.
By their numbers in this assay, from the lowest: compounds 3, 2, 4 and 1 (each within the scatter of the next, the first and the last beyond it).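

In this assay the aromatic group on the five-membered ring of the shared core gives its first measured step, a 2.2-fold higher number from compound 3 to compound 4 (0.35 log units; beyond the scatter), so this position does respond to a change, though only modestly. Replacing phenyl with 5-methyl-1,2-oxazol-3-yl keeps the count of heavy atoms the same but brings in ring nitrogen and oxygen, and inhibition becomes weaker rather than staying level. Nothing available here accounts for this loss.

As far as these compounds go, it remains open whether the methyl group or the ring's hetero atoms drive the change. A 1,2-oxazol-3-yl group without the methyl, or a methylphenyl group, at this place would help separate the two, while a pyridine ring would test whether a single ring nitrogen is enough to shift the number.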